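Long acyl chains on the shared core: compounds 1 to 3

A few compounds are considered here, and "the series" means these few. Any claim that something is new, unique, unknown or untested is made for them only; others in the source may bear on it.

Compound 1 `CCCCCCCCCCC(=O)NCC(C)(C)CC1=C(O)C(=O)c2ccccc2C1=O` gives 17600 nM
Compound 2 `CCCCCCCC(=O)OCC(C)(C)CC1=C(O)C(=O)c2ccccc2C1=O` gives 38300 nM

In a functional assay on KB cells (Homo sapiens) for cytotoxicity, read by resazurin assay, with a stated time of 3 days (on this read-out higher numbers stand for weaker inhibition and lower numbers for stronger inhibition), compound 2 stands at 38300 nM as the higher of the two numbers. The gap down to compound 1 lies beyond the scatter. Compound 1 differs from compound 2 in more than one place, so it gives no clean guide to chain length alone.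

Compound 3 `CCCCCCCCCCCCCCCCCC(=O)OCC(C)(C)CC1=C(O)C(=O)c2ccccc2C1=O` is compound 2 with the change decyl in place of hydrogen on a saturated chain carbon, seven bonds along the chain from a carbonyl carbon. Among the measured compounds shown here, no measured pair isolates this change. A step within the scatter is therefore expected in this assay, leaning slightly towards stronger inhibition, though the opposite direction remains possible. The estimated 1.4-fold lower number from compound 2 to compound 3 (0.15 log units; within the scatter) is only a working expectation. For compound 3 the estimated value is 27000 nM with an expected range of 9000 nM to 80000 nM.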

Compound 3, half-maximal inhibitory concentration: 76700 nM
Beside the measured number, compound 3's estimate is 2.8-fold (0.45 log units) below it; the measured number falls inside the stated range.
By their numbers in this assay, from the lowest: compound 1; then compounds 2 and 3 (each within the scatter of the next).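

In this assay, among the compounds shown here, the pair gives the first readable step at this chain position: a 2.0-fold higher number from compound 2 to compound 3 (0.30 log units; within the scatter), with decyl in place of hydrogen on a saturated chain carbon, seven bonds along the chain from a carbonyl carbon. That step lies within the scatter, so this pair does not separate the two chain lengths, and lengthening the ester chain by decyl brings no measurable gain in inhibition here. Nothing measured on these compounds offers an explanation for the step.

The compounds shown leave open how a shorter chain, or a chain ending in an amine or a carboxylic acid, would read at this position. For the compounds shown here, they also hold no pair that sets an amide against an ester carrying the same chain, so compound 1 remains outside this comparison.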